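Adding an Ethoxycarbonyl Group to Compound 1

The source may report more compounds than this note shows. Statements on the series, on what has been measured and on what is new or still open speak of the compounds shown alone.

Compound 1 `O=C(CO[N+](=O)[O-])NNC(=O)c1ccc(-n2[nH]c(=O)cc2-c2ccc([N+](=O)[O-])cc2)cc1`: 23.6%
Compound 2 `COc1ccccc1-c1cc(=O)[nH]n1-c1ccc(C(=O)NNC(=O)CO[N+](=O)[O-])cc1`: 55.1%

Among the compounds with values here, in a functional assay on the whole organism (strain Wistar) for inhibition, with Rattus norvegicus as the target, read by paw edema, with a stated time of 1 h, at a dose of 6 mg/kg by the oral route (on this read-out lower numbers stand for less inhibition and higher numbers for more inhibition at the one dose given (going by the name of the read-out)), compound 1 gives 23.6%, the lowest of the two numbers known, and compound 2 gives 55.1%. Within the data shown here, the one measured step, a number 31.5 percentage points higher from compound 1 to compound 2 (beyond the scatter), exchanges one aryl group for another. Compound 3 `CCOC(=O)c1c(-c2ccc([N+](=O)[O-])cc2)n(-c2ccc(C(=O)NNC(=O)CO[N+](=O)[O-])cc2)[nH]c1=O` is not yet measured; it differs from compound 1 in this way: ethoxycarbonyl in place of hydrogen on an aromatic carbon. Among the measured compounds shown here, no measured step covers such an addition, so the known step offers no guide, and the expected change is none beyond the scatter: a number 1.4 percentage points higher from compound 1 to compound 3 (within the scatter). Compound 3 is therefore estimated at 25%, with a range from 8% to 45%.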

Compound 3, a percentage reported as inhibition, in the whole organism at one dose (the size of the read-out at that dose, not a potency): 27.8%
Estimate against measurement, compound 3: 2.8 percentage points below, and the stated range covers the measured number.
By their numbers in this assay, from the lowest: compounds 1 and 3 (each within the scatter of the next); then compound 2.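

In this assay, an ethoxycarbonyl group on the aromatic carbon next to the ring atom that bears a 4-nitrophenyl group gives a number 4.2 percentage points higher from compound 1 to compound 3 (within the scatter). This position therefore takes 5 added heavy atoms without a change beyond the scatter, at least with the 4-nitrophenyl group present. No available data explain this result. On these data alone, it remains open whether the same addition would behave alike in compound 2, with its 2-methoxyphenyl group. As far as these compounds go, how an amine, a carboxylic acid or a longer ester chain would fare at this carbon also remains open.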